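This account rests on a few compounds, and the source may have more. Where it says the series, first, only, none or still open, it means among the compounds named here.

Of the compounds shown here, two have so far been measured in a functional assay on the whole organism (strain L.) for inhibition, with Echinochloa crus-galli as the target, with a stated time of 72 h, tested at 10 mg/L; a lower number here means less inhibition of growth, a higher number more inhibition of growth at the concentration tested. Compound 1 `COc1cc(SC)nc(NC(=S)NC(=O)c2c(-c3ccc(Cl)cc3Cl)noc2C)n1` gives 19.3% in this assay. Compound 2 `COc1cc(OC)n2s/c(=N\C(=O)c3c(-c4ccc(Cl)cc4Cl)noc3C)nc2n1` gives 43.2% in this assay, the higher of the two numbers, and its gap to compound 1 lies beyond the usual scatter. Compound 3 `COc1cc(SC)nc2n/c(=N/C(=O)c3c(-c4ccc(Cl)cc4Cl)noc3C)sn12` differs from compound 2 in a single place: methylsulfanyl in place of methoxy on an aromatic carbon. For the measured compounds named here, no measured pair shows this exchange on the shared core, so its effect is unknown. The expected step in this assay is a number 3.2 percentage points lower from compound 2 to compound 3 (within the scatter), small and in no firm direction, likely within the scatter. Compound 3 is therefore expected to give about 40%, between 20% and 60%.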

Compound 3, percent growth inhibition at one concentration: 21.4%
Estimate against measurement, compound 3: 18.6 percentage points above, within the range that was stated.
By their numbers in this assay, from the lowest: compounds 1 and 3 (each within the scatter of the next); then compound 2.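

In this assay, methylsulfanyl in place of methoxy on this aromatic carbon gives a number 21.8 percentage points lower from compound 2 to compound 3 (beyond the scatter). This first single-place change shows that the position matters for growth inhibition at the concentration tested, and that of these two groups, methoxy gives the higher number. Nothing measured here explains the difference between the two groups. Going by these compounds, whether an amine or a longer chain such as ethoxy on this carbon would match compound 2 remains open. On these data alone, the effect of changing the other methoxy group also remains open.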